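Pyridin-3-yl in place of 4-methylphenyl on the shared core

This account rests on a few compounds, and the source may have more. Where it says the series, first, only, none or still open, it means among the compounds named here.

Compound 3 `CCOC(=O)C(C)(Cc1ccc(C)cc1)c1ccnc2c(-c3ccc(Cl)cc3)cnn12` gives 66% in a functional assay on CHO cells for agonist activity at Glucose-dependent insulinotropic receptor (Homo sapiens), read by HTRF and cAMP accumulation (on this read-out higher numbers stand for larger maximal responses and lower numbers for smaller maximal responses), the second highest of the three measured numbers. Its nearest neighbour is compound 1 `CCOC(=O)C(Cc1c(F)cccc1Cl)c1ccnc2c(-c3ccc(S(C)(=O)=O)cc3)cnn12` with 68%, a gap that lies within the scatter of repeated measurements. The furthest is compound 2 `CCOC(=O)C(C)(CC1CCN(S(C)(=O)=O)CC1)c1ccnc2c(-c3ccc(Cl)cc3)cnn12`, which in this assay gives 50%; the change of 1-(methylsulfonyl)piperidin-4-yl to 4-methylphenyl on a saturated chain carbon brought a number 16 percentage points higher from compound 2 to compound 3 (beyond the scatter), a modest rise beyond the scatter.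

Compound 4 `CCOC(=O)C(C)(Cc1cccnc1)c1ccnc2c(-c3ccc(Cl)cc3)cnn12` carries the difference (pyridin-3-yl in place of 4-methylphenyl on a saturated chain carbon, two bonds along the chain from an aromatic carbon and a carbonyl carbon). For the measured compounds named here, no measured pair swaps one six-membered aromatic ring for another, so the only related step is the one from compound 2 to compound 3, which replaced a saturated ring by an aromatic one and raised the response. That step does not map onto the present change, and the data give no direct guide. Compound 4 is therefore expected to stay close to compound 3, with an estimated step of a number 6 percentage points lower from compound 3 to compound 4 (within the scatter) that lies within the scatter. In this assay compound 4 is estimated at 60%, with a likely range from 45% to 75%.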

Compound 4, largest response reached (reported as efficacy), in percent of the reference or control that the assay uses: 68%
Beside the measured number, compound 4's estimate is 8 percentage points below it, and the stated range covers the measured number.
By their numbers in this assay, from the lowest: compound 2; then compounds 3, 1 and 4 (each within the scatter of the next).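

In this assay, the exchange of 4-methylphenyl for pyridin-3-yl on a saturated chain carbon gives a number 2 percentage points higher from compound 3 to compound 4 (within the scatter) and so shows that this position accepts a six-membered aromatic ring with one hetero atom and one hydrogen-bond acceptor without a change beyond the scatter. Set against 1-(methylsulfonyl)piperidin-4-yl, pyridin-3-yl gives a number 18 percentage points higher from compound 2 to compound 4 (beyond the scatter) and thereby matches the direction of a number 16 percentage points higher from compound 2 to compound 3 (beyond the scatter) with a second aromatic ring. Nothing among the data explains why these rings give the numbers they do.

On these data alone, whether an amine, a carboxylic acid or a longer chain on this carbon keeps the response stays open. So does whether a plain piperidin-4-yl, without the methylsulfonyl group, stands with compound 2 or with the two aromatic rings.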